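Methoxy in Place of Hydroxy: Cytotoxicity in Muscle Cells

A few compounds are considered here, and "the series" means these few. Any claim that something is new, unique, unknown or untested is made for them only; others in the source may bear on it.

Three measured compounds share one core and differ only in the group on the outer phenyl ring. Compound 3 `Cc1nc(-c2cnc3ccc(-c4ccc(O)cc4)cc3c2)no1` carries a hydroxy group there. In a functional assay on RD cells (Homo sapiens) for inhibition, read by luminescence and ATP content, with a stated time of 72 h (on this read-out higher numbers stand for lower toxicity in this test and lower numbers for higher toxicity in this test), compound 3 gives > 2500 nM, which is a limit of the assay and not a number. Compound 1 `CCc1ccc(-c2ccc3ncc(-c4noc(C)n4)cc3c2)cc1` carries an ethyl group in the same place. In this assay compound 1 gives > 7400 nM, again a limit rather than a number. Compound 2 `Cc1ccc(-c2ccc3ncc(-c4noc(C)n4)cc3c2)cc1` carries a methyl group. In this assay compound 2 gives > 7400 nM, also a limit. Compound 3 thus sits at the limit of > 2500 nM in this assay, at which 1 of the 3 values shown sits, while the two other compounds sit at the limit of > 7400 nM in this assay, at which 2 of the 3 values shown sit.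

Compound 4 `COc1ccc(-c2ccc3ncc(-c4noc(C)n4)cc3c2)cc1` has not been measured. Its difference from compound 3 is methyl in place of hydrogen on an oxygen on an aromatic ring. Going by the values given here, the steps that bear on this place are a step that the two limits leave unreadable from compound 1 to compound 3 and a step that the two limits leave unreadable from compound 2 to compound 3, with a step that the two limits leave unreadable from compound 1 to compound 2 altering the chain on that carbon; none of them has a readable size or direction, since every value involved is a limit. The expectation is therefore that compound 4 stays at low toxicity, with an estimated value of 10000 nM in a range from 2500 nM to 40000 nM. The step from compound 3 to compound 4 is expected to be a step that the limit leaves unreadable from compound 3 to compound 4, nothing beyond the scatter.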

Compound 4, half-maximal cytotoxic concentration: > 66700 nM
Compound 4 was reported as a limit; the forecaster's own chance of this, stated with the estimate: 85%; middle value at least 6.6-fold (0.82 log units) away from the limit.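

In this assay compound 4 is reported only as a limit and not a number: the limit of > 66700 nM in this assay, at which 1 of the 4 values shown sits.

Going by these compounds alone, compound 1, compound 2 and compound 3 are limits too, and no step from any of them to compound 4 can be read. On these data alone, what stays open is the actual toxicity of all four compounds, and whether swapping methoxy, hydroxy, methyl or ethyl changes it at all.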